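A Urea Swap Tested Against the Assay Limit

The source may hold more compounds than are shown below. What is called first, only, known or untested is meant among the compounds shown, and "the series" means these compounds.

Three compounds sharing one core were examined in a functional assay on MDA-MB-231 cells (Homo sapiens) for antiproliferative activity, read by MTT assay, with a stated time of 72 h; a lower number here means a stronger inhibitor, a higher number a weaker inhibitor. Compound 1 `CC(=O)Nc1ccc(S(=O)(=O)Nc2cccc(-c3nc(-c4ccc(NC(=O)c5cccnc5)cc4Cl)no3)c2)cc1C` carries a sulfonamide; in this assay compound 1 reaches only the limit of > 10000 nM, which is not a number. Compound 2 `CCN(CC)C(=O)Nc1ccc(S(=O)(=O)Nc2cccc(-c3nc(-c4ccc(NC(=O)c5cccnc5)cc4Cl)no3)c2)cc1` gives 8700 nM in this assay. Compound 3 `O=C(Nc1ccc(Cl)cc1)Nc1cccc(-c2nc(-c3ccc(NC(=O)c4cccnc4)cc3Cl)no2)c1` is a urea; in this assay compound 3 also stops at the limit of > 10000 nM. So compound 3 stands only as a limit, and two of the three values shown sit at the limit of > 10000 nM in this assay, at which 2 of the 3 values shown sit; only compound 2 yields a number, and a weak one.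

Compound 4 `C#Cc1cccc(NC(=O)Nc2cccc(-c3nc(-c4ccc(NC(=O)c5cccnc5)cc4Cl)no3)c2)c1` differs from compound 3 by 3-ethynylphenyl in place of 4-chlorophenyl on an amide-type nitrogen. Among the measured compounds shown here, no measured pair shows what this exchange does, so its size can only be anticipated. Given that compound 3 sits at a limit, the expected step of a number no higher from compound 3 to compound 4 (the limit leaves the size open) is none beyond the scatter. Compound 4 is therefore estimated at 10000 nM, within a range from 3000 nM to 30000 nM, with a fair chance that this assay again reports only a limit.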

Compound 4, half-maximal inhibitory concentration: > 10000 nM
Compound 4: only a limit was reported; the forecaster's own chance of this, stated with the estimate: 60%; the middle value sits exactly at the limit.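

Compound 3 and compound 4 both stop at a limit in this assay, so no step between them can be read: the limit of > 10000 nM in this assay, at which 3 of the 4 values shown sit.

The compounds shown leave open how 3-ethynylphenyl and 4-chlorophenyl compare on the amide-type nitrogen, and whether any urea here would give a number in this assay.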